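This account rests on a few compounds, and the source may have more. Where it says the series, first, only, none or still open, it means among the compounds named here.

Measured compounds:
compound 1 `O=C(NO)c1ccc(NC2CCN(c3ccc4ccccc4c3)C2=O)cc1` — in an assay on isolated protein for inhibition of protein deacetylase HDAC6 (Homo sapiens) (a lower number here means a stronger inhibitor, a higher number a weaker inhibitor), compound 1 is recorded as "not determined" (no result reported)
compound 2 `CS(=O)(=O)c1ccc(N2CCC(Nc3ccc(C(=O)NO)cc3)C2=O)cc1` — in this assay compound 2 gives 140 nM

Among the measured compounds shown here, compound 2 is therefore the only compound of the pair with a number in this assay; compound 1 carries no result there, so compound 2 stands alone and cannot be ranked against anything measured. The account now turns to compound 3 `O=C(NO)c1ccc(NC2CCN(c3ccc(C(F)(F)F)cc3)C2=O)cc1`, which has not yet been measured in this assay. Compound 3 differs from compound 2 in one place: trifluoromethyl in place of methylsulfonyl on an aromatic carbon. Both compounds keep the hydroxamic acid and the shared core unchanged.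

For the measured compounds named here, no step between two measured compounds is available to calibrate this exchange, so the expectation rests on the single value of compound 2 and on the fact that the altered group sits far from the hydroxamic acid. The step from compound 2 to compound 3 is expected to be small, with no clear direction beyond the usual scatter, as a 1.1-fold higher number from compound 2 to compound 3 (0.03 log units; within the scatter). On that basis compound 3 is estimated at 150 nM in this assay, within a range from 50 nM to 450 nM.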

Compound 3, half-maximal inhibitory concentration: 250 nM
Estimate against measurement, compound 3: 1.7-fold (0.22 log units) below; low and high end bracket the measured number.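

Among the compounds shown here, this exchange gives the first reading at this place on the aromatic ring: in this assay, trifluoromethyl in place of methylsulfonyl, para to a large group, amounts to a 1.8-fold higher number from compound 2 to compound 3 (0.25 log units; within the scatter), so the values of compound 2 and compound 3 cannot be told apart. The exchange keeps the count of heavy atoms but goes from two hydrogen-bond acceptors and two double bonds outside aromatic rings to none of either, and in this pair that difference does not carry the values beyond the usual scatter, which neither compound alone could show. No measurement at hand bears on why the two groups give values this close.

Steps to compound 1 cannot be read, since it has no number in this assay, and a single pair cannot show whether the same holds for other groups on this aromatic carbon. From the compounds shown here alone, it remains open whether an amine, a carboxylic acid or a longer chain at this place would stay within the scatter of compound 2 and compound 3 or would move the number clearly in either direction.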